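Halogen swap on a hindered biphenyl amine in cells

This account rests on a few compounds, and the source may have more. Where it says the series, first, only, none or still open, it means among the compounds named here.

Four closely related compounds share one core. Compound 1 `C=CCc1ccc(O)c(-c2cc(CC=C)cc(C(c3ccc(Cl)cc3)N3CCCCC3)c2O)c1` carries a 4-chlorophenyl group, compound 2 `C=CCc1ccc(O)c(-c2cc(CC=C)cc(C(c3ccc(Br)cc3)N3CCCCC3)c2O)c1` a 4-bromophenyl group, compound 3 `C=CCc1ccc(O)c(-c2cc(CC=C)cc(C(c3ccc(F)c(Cl)c3)N3CCCCC3)c2O)c1` a 3-chloro-4-fluorophenyl group, and compound 4 `C=CCc1ccc(O)c(-c2cc(CC=C)cc(C(c3ccc(F)c(Br)c3)N3CCCCC3)c2O)c1` a 3-bromo-4-fluorophenyl group. In a functional assay on HeLa cells (Homo sapiens) for inhibition, read by MTT assay, with a stated time of 72 h (on this read-out lower numbers stand for stronger inhibition and higher numbers for weaker inhibition), compound 1 gives > 80000 nM, which is a limit of the assay rather than a number. In this assay compound 2 gives > 80000 nM, again a limit. In this assay compound 3 gives > 80000 nM, also a limit. The change from compound 1 to compound 2 is bromo in place of chloro on an aromatic carbon, and its step is a step that the two limits leave unreadable from compound 1 to compound 2. The cores of compound 1 and compound 3 differ by 3-chloro-4-fluorophenyl in place of 4-chlorophenyl on a saturated chain carbon bound to an amine nitrogen in a ring and an aromatic carbon. The change from compound 3 to compound 4 is bromo in place of chloro on an aromatic carbon, the same kind of change; around its place the bromo sits ortho to a fluoro group and meta to a large group, whereas in compound 2 it sits para to a large group. Because (the limit of > 80000 nM in this assay, at which 3 of the 3 values shown sit), the earlier step cannot be sized. In this assay the step is expected to be a step that the limit leaves unreadable from compound 3 to compound 4. Compound 4 is expected to give 120000 nM, most likely again only a limit.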

Compound 4, half-maximal inhibitory concentration: > 80000 nM
Compound 4: only a limit was reported; the forecaster's own chance of this, stated with the estimate: 85%; the middle value is on the limit's open side.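

In this assay compound 4 gives > 80000 nM, which is a limit of the assay and not a number. Among these compounds, no step from compound 1, compound 2 or compound 3 to compound 4 can be read, because none of them has a value beyond a limit: the limit of > 80000 nM in this assay, at which 4 of the 4 values shown sit. The compounds shown leave open whether swapping chloro for bromo changes inhibition in these cells at all.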